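Notes on compound 4 in the series

The source may hold more compounds than are shown below. What is called first, only, known or untested is meant among the compounds shown, and "the series" means these compounds.

The shared core of compound 1 `COc1cc(C=c2s/c(=C3\C(=O)Nc4ccc(F)cc43)n(CCN(C)C)c2=O)cc(OC)c1OC` carries a 3,4,5-trimethoxyphenyl group on a double-bonded chain carbon; in an ADME assay on WI-38 cells (Homo sapiens) for inhibition, read by MTT assay, with a stated time of 72 h (on this read-out lower numbers stand for stronger inhibition and higher numbers for weaker inhibition), compound 1 gives 8100 nM. Compound 2 `CCN(CC)CCCn1c(=O)c(=Cc2cc(OC)c(OC)c(OC)c2)s/c1=C1\C(=O)Nc2ccc(C)cc21` keeps the same 3,4,5-trimethoxyphenyl group, but in this assay compound 2 gives "not determined" (no result reported); nothing further was reported for it. In this assay compound 3 `CCN(CC)CCCn1c(=O)c(=Cc2ccccc2O)s/c1=C1\C(=O)Nc2ccc(Br)cc21` likewise gives "not determined" (no result reported) and so stands without a number. For the measured compounds named here, compound 2 therefore cannot be placed on the scale by its own reading, and the only single number is that of compound 1.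

Compound 4 `CCN(CC)CCCn1c(=O)c(=Cc2ccc(O)cc2)s/c1=C1\C(=O)Nc2ccc(C)cc21` differs from compound 2 in one place: 4-hydroxyphenyl in place of 3,4,5-trimethoxyphenyl on a double-bonded chain carbon bound to an aromatic carbon. Going by the values given here, no pair of measured compounds shows this change, so the size and direction of its step in this assay are unknown; the single reading of compound 1 is the only anchor, and the change from compound 2 to compound 4 may move the number in either direction or leave it within the scatter. Compound 4 is expected to fall around 10000 nM, within the range 2000 nM to 50000 nM.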

Compound 4, half-maximal inhibitory concentration: 5750 nM
Beside the measured number, compound 4's estimate is 1.7-fold (0.24 log units) above it; the measured number falls inside the stated range.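

In this assay compound 4 gives 5750 nM, but compound 2 has no single number, so no step can be read between compound 2 and compound 4, and nothing shown bears on a cause. The compounds shown leave open how 4-hydroxyphenyl in place of 3,4,5-trimethoxyphenyl moves the number.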